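Acetylation of a sugar hydroxyl on a prenylated hydroquinone

The source may hold more compounds than are shown below. What is called first, only, known or untested is meant among the compounds shown, and "the series" means these compounds.

Measured so far:
compound 1, `CC(=O)OCC(O)(C(Cc1cc(O)c(C)cc1O)OC(C)=O)C12CCC(C)(CC(/C=C(\C)CCC=C(C)C)O1)O2`, 1.2 ug/mL
compound 2, `CC(C)=CCC/C(C)=C/CC/C(C)=C/CC/C(C)=C/Cc1cc(O[C@@H]2OC[C@@H](O)[C@@H](O)[C@@H]2O)c(C)cc1O`, 2 ug/mL

Of the compounds shown here, two have been tested in a functional assay on P388 cells (Mus musculus) for cytotoxicity; on this read-out higher numbers stand for weaker inhibition and lower numbers for stronger inhibition. Compound 1 gives 1.2 ug/mL in this assay, and compound 2 gives 2 ug/mL. The two numbers lie within the usual scatter of each other, so neither compound can be called the stronger one on the evidence at hand.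

Compound 3, `CC(=O)O[C@@H]1CO[C@@H](Oc2cc(C/C=C(\C)CC/C=C(\C)CC/C=C(\C)CCC=C(C)C)c(O)cc2C)[C@@H](O)[C@@H]1O`, has not yet been measured in this assay. It differs from compound 2 in a single place: acetyl in place of hydrogen on an oxygen on a saturated carbon. The change sits on one of the hydroxyls of the sugar part of the molecule, while the long chain and the core are left as they are.

Going by the values given here, no pair of measured compounds shows what such a change does here, so there is no measured step to lean on. The expectation is therefore cautious: the step is expected to be small, no change at the digits printed from compound 2 to compound 3 (within the scatter), not clearly beyond the scatter in either direction. Compound 3 is thus estimated to give about 2 ug/mL in this assay, with a range from 0.8 ug/mL to 5 ug/mL.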

Compound 3, half-maximal inhibitory concentration: 2 ug/mL
Compound 3: middle estimate and measured number agree at the digits printed; the range from low to high includes it.
By their numbers in this assay, from the lowest: compounds 1, 2 and 3 (each within the scatter of the next).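

Going by these compounds alone, replacing hydrogen with acetyl on this oxygen of the sugar gives, in this assay, no change at the digits printed from compound 2 to compound 3 (within the scatter), and this is the first measured step at any position. In this one pair, the free hydroxy group at this place on the sugar is therefore not needed to keep the cytotoxic read-out at the level of compound 2, and the hydroxy to acetoxy swap leaves the number where it was, with the long chain and the core unchanged. Nothing measured alongside these numbers indicates why the value stays the same, so the result remains a plain observation without an explanation.

The compounds shown leave open whether this oxygen would accept something other than acetyl, such as a methyl ether or a benzoyl ester, and whether an acetyl on either of the remaining sugar hydroxyls would behave in the same way. Compound 1 differs from compound 2 and compound 3 in more than one place, so it cannot settle these questions, and neither can it show what removing the whole sugar would do.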